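A few compounds are considered here, and "the series" means these few. Any claim that something is new, unique, unknown or untested is made for them only; others in the source may bear on it.

Two compounds in this series have numbers in a functional assay on the whole organism with Mus musculus as the target, with a stated time of 20 min; on this read-out lower numbers stand for an effect already at smaller amounts and higher numbers for an effect only at larger amounts of compound. Compound 1 `CC(C)S(=O)(=O)Nc1ccc(N(C)C(=O)c2ccccc2)cc1` gives 0.1 mg/kg, the lowest of the two; compound 2 `CCC(=O)N[C@H]1CC[C@@H](NC(=O)CC)CC1` gives 1 mg/kg, a gap beyond the usual scatter. Compound 3 `CC(C)S(=O)(=O)Nc1ccc(NC(=O)c2ccccc2)cc1` is unmeasured. It differs from compound 1 by hydrogen in place of methyl on an amide-type nitrogen. Within the data shown here, no pair of measured compounds shows the effect of this change, so the step is expected to be small, with no direction supported beyond the scatter: a 1.5-fold higher number from compound 1 to compound 3 (0.18 log units; within the scatter). For compound 3 in this assay a minimum effective dose of 0.15 mg/kg is expected, within 0.05 mg/kg to 0.5 mg/kg.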

Compound 3, minimum effective dose: 10 mg/kg
The estimate for compound 3 lay 67-fold (1.82 log units) below the measured number, outside the stated range (above it).
By their numbers in this assay, from the lowest: compound 1; then compound 2; then compound 3.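

Methyl on the amide-type nitrogen matters in this assay: hydrogen in its place gives a 100-fold higher number from compound 1 to compound 3 (2.00 log units; beyond the scatter) and so makes this the first one-place change in the series with a readable effect. Loss of a single carbon here is enough to move the number well beyond the scatter. No measurement at hand explains the size of this step.

From the compounds shown here alone, whether ethyl or a longer chain on this nitrogen would match methyl or move the number further stays open. Also open, going by these compounds, is whether an acetyl group at this nitrogen could take the place of methyl.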